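Chalcone series: dimethoxyphenyl placement ahead of the next measurement

The source may report more compounds than this note shows. Statements on the series, on what has been measured and on what is new or still open speak of the compounds shown alone.

The series is followed in a functional assay on MCF7 cells (Homo sapiens) for cytotoxicity, read by sulforhodamine B assay, with a stated time of 48 h; a higher number here means a weaker inhibitor, a lower number a stronger inhibitor. Compound 1 `COc1ccc(/C=C/C(=O)c2cccc(-c3cccc(F)c3)c2)cc1` is the lower of the two numbers available: in this assay compound 1 gives 3080 nM. Compound 2 `COc1ccc(/C=C/C(=O)c2cccc(-c3cccc(F)c3)c2)cc1O` carries no result in this assay; its entry reads "not determined" (no result reported), so it contributes no number to the comparison. Compound 3 `COc1ccc(-c2cc(C(=O)/C=C/c3cccc(OC)c3OC)ccc2N)cc1OC` holds the highest number of the two reported: in this assay compound 3 gives 10200 nM, which sits beyond the scatter of the value of compound 1. Nothing between compound 1 and compound 3 is a single change, so the gap between them is only described by the two values themselves.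

The step under consideration leads from compound 3 to compound 4 `COc1ccc(/C=C/C(=O)c2ccc(N)c(-c3ccc(OC)c(OC)c3)c2)c(OC)c1`. The two share every atom and differ only in how they are joined: 2,4-dimethoxyphenyl in place of 2,3-dimethoxyphenyl on a double-bonded chain carbon bound to a double-bonded chain carbon. Among the compounds with values here, no measured pair shows a change of this kind, so there is no reference step to lean on. The expectation for compound 4 is therefore a modest step at most, with a 1.3-fold lower number from compound 3 to compound 4 (0.11 log units; within the scatter) judged to lie within the usual scatter rather than beyond it, leaning if anything to a slightly lower number. On that basis compound 4 is estimated at 8000 nM in this assay, with a plausible range from 3000 nM to 25000 nM.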

Compound 4, half-maximal inhibitory concentration: 6490 nM
For compound 4 the middle estimate is 1.2-fold (0.09 log units) above the measured one; the range from low to high includes it.
By their numbers in this assay, from the lowest: compound 1; then compounds 4 and 3 (each within the scatter of the next).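

In this assay, within the data shown here, 2,4-dimethoxyphenyl in place of 2,3-dimethoxyphenyl on a double-bonded chain carbon bound to a double-bonded chain carbon gives a 1.6-fold lower number from compound 3 to compound 4 (0.20 log units; within the scatter), and this is the only single-place step so far. The two groups match in heavy atoms, ring and hydrogen-bond counts, and this read-out does not separate them, so at this place the exchange of one dimethoxyphenyl for the other registers no change beyond the scatter. No accompanying measurement bears on this result, and the pair offers no explanation for it.

Still open, going by these compounds, is whether a larger change at this place would move the number beyond the scatter, for example a trimethoxyphenyl or a phenyl carrying a carboxylic acid on the same double-bonded chain carbon. Among these compounds, also open is whether the same exchange of 2,3-dimethoxyphenyl for 2,4-dimethoxyphenyl would read the same way on another core, such as the core of compound 1, as this single pair is the only reading of the change.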